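This account rests on a few compounds, and the source may have more. Where it says the series, first, only, none or still open, it means among the compounds named here.

Compound 2, `Nc1ccccc1NC(=O)c1ccc(CSC(=S)N2CCN(Cc3cccnc3)CC2)cc1`, belongs to a pair of benzamide-linked dithiocarbamates measured in a functional assay on A-375 cells (Homo sapiens) for antiproliferative activity, read by CCK-8 assay, with a stated time of 72 h, tested at 8 uM (on this read-out higher numbers stand for a stronger effect at the one concentration tested and lower numbers for a weaker effect), where compound 2 gives 89.2%. For the measured compounds named here, its only companion is compound 1, `Nc1ccccc1NC(=O)c1ccc(CSC(=S)N2CCN(Cc3ccncc3)CC2)cc1`, which in this assay gives 89.5%; the two numbers sit within the scatter of each other, so compound 2 stands alongside compound 1 rather than apart from it. Going by the values given here, the single measured step, a number 0.3 percentage points lower from compound 1 to compound 2 (within the scatter), shows that moving the ring nitrogen of the pyridine did not change the read-out beyond the scatter.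

Compound 3, `Nc1ccccc1NC(=O)c1ccc(CSC(=S)N2CCN(c3ccncc3)CC2)cc1`, is not yet measured. It differs from compound 2 by pyridin-4-yl in place of (pyridin-3-yl)methyl on an amine nitrogen in a ring. Among the compounds with values here, the measured step bears on this change only in part: it covered the position of the ring nitrogen on an attached pyridine, whereas here the saturated chain carbon between the ring nitrogen and the pyridine is also lost, and no measured step speaks to that. Within the data shown here, with the one relevant step being within the scatter, the expectation for compound 3 in this assay is a step of a number 4.2 percentage points lower from compound 2 to compound 3 (within the scatter), essentially none beyond the scatter. Compound 3 is therefore estimated at 85%, between 68% and 95%.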

Compound 3, a percentage reported as inhibition, at one concentration (the size of the read-out at that concentration, not a potency): 90.7%
Beside the measured number, compound 3's estimate is 5.7 percentage points below it, within the range that was stated.
By their numbers in this assay, from the lowest: compounds 2, 1 and 3 (each within the scatter of the next).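

On the amine nitrogen in a ring, the earlier pair had varied only where the ring nitrogen of the pyridine stands, whereas compound 3 also removes the saturated chain carbon, and this assay records a number 1.5 percentage points higher from compound 2 to compound 3 (within the scatter). The comparison that changes only this carbon, with pyridin-4-yl kept, gives a number 1.2 percentage points higher from compound 1 to compound 3 (within the scatter), so the read-out does not separate (pyridin-4-yl)methyl from pyridin-4-yl at this position, and the attached pyridine can lose that carbon with no change beyond the scatter. Nothing measured alongside these numbers offers an explanation for this result.

The compounds shown leave open whether the pyridine ring nitrogen matters at all on this amine nitrogen, and how a plain phenyl ring, a small methyl group, a carboxylic acid or a longer chain carrying the pyridine would read there. Since all three compounds were read at one concentration, they also leave open whether a full concentration series would separate them, as a single percentage is not a potency.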